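The source may report more compounds than this note shows. Statements on the series, on what has been measured and on what is new or still open speak of the compounds shown alone.

Of the compounds shown here, three sharing one core have been measured in an assay on isolated protein for inhibition of Leucine-rich repeat serine/threonine-protein kinase 2 (Homo sapiens), in the presence of a further agent that is not named here; a lower number here means a stronger inhibitor, a higher number a weaker inhibitor. Compound 1 `COc1ccc(OC)c(Sc2ccc3nnc(-c4ccccn4)n3n2)c1` gives 496 nM. Compound 2 `COc1ccc(OC)c(Sc2ccc3nnc(-c4cccnc4)n3n2)c1` gives 242 nM, and compound 3 `COc1cncc(-c2nnc3ccc(Sc4cc(OC)ccc4OC)nn23)c1` gives 66 nM. Compound 2 therefore holds the second highest of the three numbers: its nearest neighbour is compound 1, with a 2.0-fold lower number from compound 1 to compound 2 (0.31 log units; beyond the scatter), and its furthest is compound 3, with a 3.7-fold lower number from compound 2 to compound 3 (0.56 log units; beyond the scatter).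

Compound 4 `COc1ccc(OC)c(Sc2ccc3nnc(-c4cn(C)nc4C)n3n2)c1` has not yet been measured. It differs from compound 2 in a single place: 1,3-dimethyl-1H-pyrazol-4-yl in place of pyridin-3-yl on an aromatic carbon.

Among the compounds with values here, only three measured steps touch this part of the molecule. Exchanging one six-membered ring for another gave a 2.0-fold lower number from compound 1 to compound 2 (0.31 log units; beyond the scatter), adding a methoxy to that ring gave a 3.7-fold lower number from compound 2 to compound 3 (0.56 log units; beyond the scatter), and the two changes together gave a 7.5-fold lower number from compound 1 to compound 3 (0.88 log units; beyond the scatter). Each of these is modest, and none replaces a six-membered ring with a five-membered one carrying two nitrogens, so they show only how much variation this position has tolerated so far, not the direction the present swap will take. A step of modest size in either direction is therefore the most that can be expected, and a result within the scatter of compound 2 is quite possible.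

On that basis compound 4 is expected to give 300 nM in this assay, with a range from 80 nM to 1200 nM, which would mean an estimated 1.2-fold higher number from compound 2 to compound 4 (0.09 log units; within the scatter).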

Compound 4, half-maximal inhibitory concentration: 323 nM
Compound 4: the middle estimate sits 1.1-fold (0.03 log units) below what was measured; the range from low to high includes it.
By their numbers in this assay, from the lowest: compound 3; then compounds 2, 4 and 1 (each within the scatter of the next, the first and the last beyond it).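

In this assay, the place on an aromatic carbon of a five-membered aromatic ring with 3 nitrogen now proves able to carry a five-membered ring as well as a six-membered one: 1,3-dimethyl-1H-pyrazol-4-yl in place of pyridin-3-yl gives a 1.3-fold higher number from compound 2 to compound 4 (0.13 log units; within the scatter), and in place of pyridin-2-yl it gives a 1.5-fold lower number from compound 1 to compound 4 (0.19 log units; within the scatter), so neither step can be told apart from repeat-measurement noise. Changing the ring size and the number of ring nitrogens together therefore leaves compound 4 level with both simple pyridine compounds, whereas 5-methoxypyridin-3-yl remains set apart, with a 4.9-fold higher number from compound 3 to compound 4 (0.69 log units; beyond the scatter) on going to the pyrazole. Nothing is available that explains these numbers.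

The compounds shown leave open how much of the result of compound 4 depends on its two methyl groups, and whether a methoxy on the pyrazole ring would lower the number as it did on the pyridine ring of compound 3. Also open, going by these compounds, is how this position would respond to a ring bearing an amine or a carboxylic acid, or to a longer chain.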